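The source may hold more compounds than are shown below. What is called first, only, known or untested is meant among the compounds shown, and "the series" means these compounds.

Three close relatives of a shared core were tested in a functional assay on HeLa cells (Homo sapiens) for cytotoxicity, read by CCK-8 assay; a lower number here means a stronger inhibitor, a higher number a weaker inhibitor. Compound 1 `Oc1cccc(-c2cc(-c3ccsc3)cc(-c3ccccc3O)n2)c1` carries a thiophen-3-yl group and a 3-hydroxyphenyl group on that core. In this assay compound 1 gives only a limit, > 50000 nM. Compound 2 `Oc1ccc(-c2cc(-c3ccsc3)cc(-c3ccccc3O)n2)cc1` arises from compound 1 through (4-hydroxyphenyl in place of 3-hydroxyphenyl on an aromatic carbon). In this assay compound 2 also gives only a limit, > 50000 nM. Compound 3 `Oc1cccc(-c2cc(-c3ccoc3)cc(-c3ccccc3O)n2)c1` differs from compound 1 through (furan-3-yl in place of thiophen-3-yl on an aromatic carbon). In this assay compound 3 likewise gives only a limit, > 50000 nM. Because all three sit at the limit of > 50000 nM in this assay, at which 3 of the 3 values shown sit, the steps a step that the two limits leave unreadable from compound 1 to compound 2 and a step that the two limits leave unreadable from compound 1 to compound 3 cannot be sized.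

Compound 4 `Oc1ccc(-c2cc(-c3ccoc3)cc(-c3ccccc3O)n2)cc1` has not yet been measured in this assay. It is reached from compound 3 through (4-hydroxyphenyl in place of 3-hydroxyphenyl on an aromatic carbon), the same kind of change as that from compound 1 to compound 2, differing only in that the place is meta to a furan-3-yl group rather than meta to a thiophen-3-yl group. Because compound 3 rests at the limit (the limit of > 50000 nM in this assay, at which 3 of the 3 values shown sit), compound 4 is expected to show the step that the limit leaves unreadable from compound 3 to compound 4. Compound 4 is therefore estimated at 100000 nM, most probably again reported only as a limit.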

Compound 4, half-maximal inhibitory concentration: > 50000 nM
Compound 4 ended at the assay's limit; the forecaster's own chance of this, stated with the estimate: 85%; the middle value does not contradict the limit.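

No step can be sized between compound 3 and compound 4 or between compound 2 and compound 4, because all of these compounds give only a limit in this assay: the limit of > 50000 nM in this assay, at which 4 of the 4 values shown sit.

The compounds shown leave open whether 4-hydroxyphenyl in place of 3-hydroxyphenyl, or furan-3-yl in place of thiophen-3-yl, changes potency at all.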